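Removing One Methyl from the Dimethyl Chloro Benzyl Group

The compounds below may be only part of what the source reports. "The series", "measured", "known", "first", "only" and "open" are said of these compounds alone.

Measured so far:
Compound 1, `CCC(C)(C)/N=c1\c(O)c(O)\c1=N/Cc1cc(F)cc(F)c1` — 750 nM
Compound 2, `CCC(C)(C)/N=c1\c(O)c(O)\c1=N/Cc1c(C)cc(C)cc1Cl` — 200 nM

Of the compounds shown here, two have been measured in a functional assay for inhibition, with Rattus norvegicus as the target; a lower number here means a stronger inhibitor, a higher number a weaker inhibitor. Compound 1 gives 750 nM there, and compound 2 gives 200 nM. Of the two numbers, compound 2 holds the lower one, and the gap between the two values is beyond the usual scatter of such measurements, so compound 2 is the stronger inhibitor of the pair. Within the data shown here, the two compounds differ in several places at once, so no single structural step between them can be read from their values.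

Compound 3, `CCC(C)(C)/N=c1\c(O)c(O)\c1=N/Cc1c(C)cccc1Cl`, has not yet been measured. It differs from compound 2 in one place: hydrogen in place of methyl on an aromatic carbon. Among the measured compounds shown here, since no measured pair shows what a single change of this kind does here, the expectation rests on the size of the change alone: a single carbon leaves and nothing takes its place. A small step is expected, leaning toward a weaker inhibitor, and possibly none beyond the scatter. The expected step is a 1.8-fold higher number from compound 2 to compound 3 (0.24 log units; within the scatter). Compound 3 is therefore estimated at 350 nM, within a range of 120 nM to 1000 nM.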

Compound 3, half-maximal inhibitory concentration: 4400 nM
Estimate against measurement, compound 3: 13-fold (1.10 log units) below; the whole stated range lies below it.
By their numbers in this assay, from the lowest: compound 2; then compound 1; then compound 3.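

Hydrogen in place of methyl on this aromatic carbon, which stands para to a large group, brings a 22-fold higher number from compound 2 to compound 3 (1.34 log units; beyond the scatter) in this assay, a step far beyond the scatter. Among these compounds, as the only step between compounds that differ in one place, it shows that this position is sensitive: the loss of one carbon, with no hydrogen-bond donor, no hydrogen-bond acceptor and no net charge involved, is enough to give a much weaker inhibitor. Nothing measured here explains why this methyl matters so much.

The compounds shown carry only methyl or hydrogen at this position, so they leave open whether an ethyl, a methoxy or a chloro group there would match methyl, improve on it or fall toward hydrogen. They also leave open whether removing this methyl would cost as much with a different group in place of the chloro group or the remaining methyl on the same ring.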